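One ring exchanged: from compound 3 to compound 4

The source may hold more compounds than are shown below. What is called first, only, known or untested is meant among the compounds shown, and "the series" means these compounds.

In a physicochemical assay for solubility, at pH 6.8 (on this read-out higher numbers stand for higher solubility and lower numbers for lower solubility), compound 1 (`CNCc1cc(Oc2ccc3c(ccn3C(=O)Nc3cccc(C(F)(F)F)c3)c2)ncn1`) gives 64000 nM, compound 2 (`CC(C)c1cc(NC(=O)n2ccc3cc(Oc4ncnc5c4CCNC5)ccc32)n[nH]1`) gives 833000 nM and compound 3 (`CC(C)(C)c1cc(NC(=O)n2ccc3cc(Oc4ncnc5c4CCNC5)ccc32)n[nH]1`) gives 682000 nM. Compound 3 thus stands level with compound 2 within the scatter and beyond the scatter from compound 1, whose number is lower. Compound 4 (`CC(C)(C)c1cc(NC(=O)n2ccc3cc(Oc4ncnc5c4CCNC5)ccc32)no1`) carries 5-(tert-butyl)-1,2-oxazol-3-yl in place of 5-(tert-butyl)-1H-pyrazol-3-yl on an amide-type nitrogen. Within the data shown here, the only measured step, a 1.2-fold lower number from compound 2 to compound 3 (0.09 log units; within the scatter), lies within the scatter and concerns a different change, so no measurement covers this exchange directly. A modest move to a lower number in this assay is expected, namely a 2.3-fold lower number from compound 3 to compound 4 (0.36 log units; beyond the scatter). For compound 4 the estimated value is 300000 nM, with an expected range of 70000 nM to 750000 nM.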

Compound 4, solubility: 167000 nM
The estimate for compound 4 lay 1.8-fold (0.25 log units) above the measured number, and the stated range covers the measured number.
By their numbers in this assay, from the lowest: compound 1; then compound 4; then compounds 3 and 2 (each within the scatter of the next).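

In this assay, 5-(tert-butyl)-1,2-oxazol-3-yl in place of 5-(tert-butyl)-1H-pyrazol-3-yl on the amide-type nitrogen gives a 4.1-fold lower number from compound 3 to compound 4 (0.61 log units; beyond the scatter), so a change at this position now moves the number beyond the scatter, which the step between the two pyrazoles did not. The step from the isopropyl pyrazole, a 5.0-fold lower number from compound 2 to compound 4 (0.70 log units; beyond the scatter), points the same way. No supporting measurement accounts for these steps. Still open, on these data alone, is how this assay would read for a 1,2-oxazol-3-yl carrying an aminomethyl group or a carboxylic acid in place of tert-butyl.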